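The source may report more compounds than this note shows. Statements on the series, on what has been measured and on what is new or still open speak of the compounds shown alone.

Of the compounds shown here, two built on one shared core have so far been tested in an assay on isolated protein for inhibition of MAP kinase-activated protein kinase 5 (Homo sapiens), read by mobility shift assay, tested at 30 uM; on this read-out higher numbers stand for more inhibition at the one concentration tested (going by the name of the read-out) and lower numbers for less inhibition. Compound 1 `Cc1cc2c(c(N)nn2C)c(N2CC[C@H](O)C2)n1` gives 1% in this assay, and compound 2 `COCCNc1nc(C)cc2c1c(N)nn2C` gives 5%. Among the compounds with values here, the single measured step between them is a number 4 percentage points higher from compound 1 to compound 2 (within the scatter), the change being (2-methoxyethyl)amino in place of 3-hydroxypyrrolidin-1-yl on an aromatic carbon. Among the two numbers, compound 2 holds the one that is not exceeded, yet its gap to compound 1 lies within the usual scatter, so the two cannot be told apart on the numbers alone.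

Compound 3 `COCCNc1nc(-c2ccccc2)cc2c1c(N)nn2C` differs from compound 2 by phenyl in place of methyl on an aromatic carbon. Within the data shown here, no measured step touches this position or this kind of exchange; the only step on record concerns a different substituent and stayed within the scatter. With nothing to point either way, the expected change is a number 1 percentage points higher from compound 2 to compound 3 (within the scatter), that is, none beyond the scatter. Compound 3 is therefore estimated at 6% in this assay, within a range from -6% to 22%.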

Compound 3, a percentage reported as inhibition, at one concentration (the size of the read-out at that concentration, not a potency): 1%
Estimate against measurement, compound 3: 5 percentage points above; low and high end bracket the measured number.
By their numbers in this assay, from the lowest: compounds 1, 3 and 2 (each within the scatter of the next).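

Phenyl in place of methyl on an aromatic carbon next to the ring nitrogen gives a number 4 percentage points lower from compound 2 to compound 3 (within the scatter) in this assay, the first measured exchange at this position of the shared core. The entering group brings 6 heavy atoms and a six-membered aromatic ring of carbon only, where the methyl held 1 heavy atom, yet compound 2 and compound 3 cannot be told apart on this read-out, so this larger group leaves no measurable mark at the one concentration tested. No measurement on hand explains this result.

The compounds shown leave open whether any other group at this position would lift the inhibition beyond the scatter, for example a carboxylic acid, an amine or a longer carbon chain in place of the phenyl. They also leave open whether phenyl would give the same reading with 3-hydroxypyrrolidin-1-yl in place of the (2-methoxyethyl)amino group, a pairing that would show whether the two positions act independently.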